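Trifluoromethyl in place of methyl: the next step

The source may hold more compounds than are shown below. What is called first, only, known or untested is meant among the compounds shown, and "the series" means these compounds.

Measured so far in an ADME assay on MDCK cells (Canis lupus familiaris) for cytotoxicity, read by MTT assay, with a stated time of 24 h; a lower number here means that less compound is tolerated, a higher number that more compound is tolerated:
compound 1 `N#CCCN(Cc1cccs1)S(=O)(=O)c1ccc(F)cc1`: > 205000 nM (a limit)
compound 2 `Cc1ccc(S(=O)(=O)N(CCC#N)Cc2cccs2)cc1`: 127000 nM

Within the data shown here, compound 2 stands at 127000 nM, the only true number in this assay so far. Compound 1 gives > 205000 nM, which is a limit of the assay and not a number.

Compound 3 `N#CCCN(Cc1cccs1)S(=O)(=O)c1ccc(C(F)(F)F)cc1` is still unmeasured and differs from compound 2 by trifluoromethyl in place of methyl on an aromatic carbon. The change is trifluoromethyl in place of methyl on an aromatic carbon, para to a large group. Among the measured compounds shown here, only one measured step bears on this place: methyl in place of fluoro, with an at least 1.6-fold lower number from compound 1 to compound 2 (0.20 log units; that floor lies within the scatter). For the measured compounds named here, with that single step as the only guide, no change beyond the scatter is expected in this assay, with a slight lean toward a higher number. The expected size is a 1.2-fold higher number from compound 2 to compound 3 (0.07 log units; within the scatter). For compound 3 the estimate is 150000 nM, with an expected range from 75000 nM to 300000 nM.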

Compound 3, half-maximal cytotoxic concentration: > 178000 nM
Compound 3: only a limit was reported (the forecaster's own chance of this, stated with the estimate: 35%); middle value at least 1.1-fold (0.07 log units) from the limit.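

In this assay compound 3 gives a limit of the assay and not a number: the limit of > 178000 nM in this assay, at which 1 of the 3 values shown sits.

Trifluoromethyl in place of methyl on this aromatic carbon, para to a large group, gives an at least 1.4-fold higher number from compound 2 to compound 3 (0.14 log units; that floor lies within the scatter), so the step has only a floor, and that floor does not clear the scatter. The step that joins the two limits cannot be read, and among the three groups shown at this place, methyl alone gives a true number, while fluoro in compound 1 and trifluoromethyl in compound 3 both end at limits: the limit of > 205000 nM in this assay, at which 1 of the 3 values shown sits.

As far as these compounds go, how far compound 1 and compound 3 lie past their limits stays open, so no order can be given between fluoro and trifluoromethyl, and the series still has a single true number to work from. Also open, from the compounds shown here alone, is whether an amine, a carboxylic acid or a longer chain at this place would give a true number in this assay, and whether any of them would differ from compound 2 by more than the scatter.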